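Changing the Sulfonamide Aryl Group from Compound 1 to Compound 3

The source may hold more compounds than are shown below. What is called first, only, known or untested is meant among the compounds shown, and "the series" means these compounds.

Compound 1 `O=C(Nc1ccc(S(=O)(=O)Nc2ccc(Cl)cc2)cc1)c1ccc(Cl)cc1Cl` and compound 2 `O=C(Nc1ccc(S(=O)(=O)Nc2ccccc2)cc1)c1ccc(Cl)cc1Br` share a common core and were both intended for a functional assay on HEK293 cells for agonist activity at probable G-protein coupled receptor 27 (Homo sapiens), read by a luciferase reporter and beta-arrestin recruitment, with a stated time of 10 min; a higher number here means a larger maximal response, a lower number a smaller maximal response. In this assay compound 1 gives "not determined" (no result reported); no result was reported for it, so its position cannot be stated. Compound 2, in this assay, gives 123%, a maximal response somewhat above that of the reference. Compound 3 `Cc1ccccc1NS(=O)(=O)c1ccc(NC(=O)c2ccc(Cl)cc2Cl)cc1` has not yet been measured. It differs from compound 1 by a single change, (2-methylphenyl in place of 4-chlorophenyl on a sulfonamide nitrogen). Among the measured compounds shown here, no measured pair isolates this change, so neither its size nor its direction can be read from the data; whether it moves the maximal response beyond the usual scatter is open. For the measured compounds named here, the only guide is compound 2, whose value shows that compounds of this core can reach a full response. Compound 3 is therefore expected to give about 105% in this assay, within a range of 65% to 145%.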

Compound 3, largest response reached (Emax), in percent of the reference or control that the assay uses: 32%
Estimate against measurement, compound 3: 73 percentage points above; measured number outside the range, below it.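

In this assay, among the compounds shown here, compound 3 gives 32% while compound 1 gives "not determined" (no result reported) and so offers no number for comparison, which means no step between compound 1 and compound 3 can be read. Going by these compounds, whether replacing 4-chlorophenyl with 2-methylphenyl changes the maximal response remains open. No further evidence bears on this result.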